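Swapping the aryl group on the benzylic amine of a sulfonamide series

The source may hold more compounds than are shown below. What is called first, only, known or untested is meant among the compounds shown, and "the series" means these compounds.

Three compounds share one core: a bis(trifluoromethyl)phenyl sulfonamide joined through a three-carbon chain to an amine that carries a benzyl-type group. In a functional assay on BE(2)-C cells (Homo sapiens) for inhibition, read by MTT assay, with a stated time of 72 h (on this read-out higher numbers stand for weaker inhibition of growth and lower numbers for stronger inhibition of growth), compound 1 `CC(C)(C)c1ccc(CNCCCNS(=O)(=O)c2cc(C(F)(F)F)cc(C(F)(F)F)c2)cc1` gives 2500 nM, compound 2 `O=S(=O)(NCCCNCc1ccc(Cl)c(C(F)(F)F)c1)c1cc(C(F)(F)F)cc(C(F)(F)F)c1` gives 8600 nM, and compound 3 `O=S(=O)(NCCCNCc1cccc2ccccc12)c1cc(C(F)(F)F)cc(C(F)(F)F)c1` gives 2700 nM. Compound 3 therefore sits second highest of the three numbers, close to compound 1 and well apart from compound 2. The step of a 1.1-fold higher number from compound 1 to compound 3 (0.03 log units; within the scatter) lies within the scatter, while a 3.2-fold lower number from compound 2 to compound 3 (0.50 log units; beyond the scatter) is a modest step beyond it.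

Compound 4 `COc1ccccc1CNCCCNS(=O)(=O)c1cc(C(F)(F)F)cc(C(F)(F)F)c1` differs from compound 3 in one place: 2-methoxyphenyl in place of naphthalen-1-yl on a saturated chain carbon bound to an amine nitrogen. Two earlier steps bear on this kind of exchange, one aryl for another on the same chain carbon. One of them, from compound 1 to compound 3, changed nothing beyond the scatter; the other, from compound 2 to compound 3, moved the number modestly. No exchange involving a methoxy group has been measured, so only this range of outcomes can guide the expectation. Compound 4 is expected to show a 1.5-fold higher number from compound 3 to compound 4 (0.17 log units; within the scatter), giving an estimated value of 4000 nM, with a range from 1500 nM to 11000 nM in this assay.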

Compound 4, concentration for 50% growth inhibition: 3600 nM
Compound 4: middle estimate off by 1.1-fold (0.05 log units), on the high side; measured number inside the range.
By their numbers in this assay, from the lowest: compounds 1, 3 and 4 (each within the scatter of the next); then compound 2.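

In this assay, 2-methoxyphenyl brings one aromatic ring and a hydrogen-bond acceptor where naphthalen-1-yl has two rings and no acceptor, yet a 1.3-fold higher number from compound 3 to compound 4 (0.12 log units; within the scatter) stays within the scatter, as does a 1.4-fold higher number from compound 1 to compound 4 (0.16 log units; within the scatter) when 4-(tert-butyl)phenyl is the group replaced. This position therefore takes an oxygen-bearing aryl group without a change that can be told from the scatter, and among these four compounds only compound 2 stands apart, with a 2.4-fold lower number from compound 2 to compound 4 (0.38 log units; beyond the scatter) lying beyond the scatter. No evidence is available here on what lies behind this pattern.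

The compounds shown leave open whether a non-aromatic group such as cyclohexyl, or a carboxylic acid on the aryl ring, would fit this pattern. They also leave open how a longer chain between the sulfonamide and the amine would read.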